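Cytotoxicity of a Urea Series: Fluoro to Iodo Swap

A few compounds are considered here, and "the series" means these few. Any claim that something is new, unique, unknown or untested is made for them only; others in the source may bear on it.

Of the compounds shown here, three built on one shared core have been measured in a toxicity assay on MRC5 cells (Homo sapiens) for inhibition, read by MTT assay, with a stated time of 72 h; on this read-out lower numbers stand for stronger inhibition and higher numbers for weaker inhibition. Compound 1 `N#Cc1cccc(-n2cc(COc3cccc(NC(=O)Nc4ccc(Cl)c(C(F)(F)F)c4)c3)nn2)c1` gives 2960 nM. Compound 2 `CC(C)c1cccc(-n2cc(COc3cccc(NC(=O)Nc4ccc(Cl)c(C(F)(F)F)c4)c3)nn2)c1` gives 21400 nM. Compound 3 `O=C(Nc1cccc(OCc2cn(-c3ccc(F)cc3)nn2)c1)Nc1ccc(Cl)c(C(F)(F)F)c1` gives 4740 nM, which places it second highest of the three numbers: compound 3 and compound 1 sit within the scatter of each other, while a 4.5-fold lower number from compound 2 to compound 3 (0.65 log units; beyond the scatter) separates it clearly from compound 2.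

Compound 4 `O=C(Nc1cccc(OCc2cn(-c3ccc(I)cc3)nn2)c1)Nc1ccc(Cl)c(C(F)(F)F)c1` differs from compound 3 by a single change: iodo in place of fluoro on an aromatic carbon. Among the compounds with values here, no measured step swaps one halogen for another. Within the data shown here, the steps that bear on this ring are a 1.6-fold higher number from compound 1 to compound 3 (0.20 log units; within the scatter) and a 7.2-fold higher number from compound 1 to compound 2 (0.86 log units; beyond the scatter), so changes on this ring have produced anything from no shift to a modest rise in this assay. An exchange of one halogen for another is a smaller alteration than those, so only a small shift, if any, is expected for compound 4, with the higher side slightly favoured, meaning a 1.5-fold higher number from compound 3 to compound 4 (0.17 log units; within the scatter). Compound 4 is therefore estimated at 7000 nM, within a range of 2500 nM to 20000 nM.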

Compound 4, half-maximal inhibitory concentration: 6840 nM
Beside the measured number, compound 4's estimate is 1.0-fold (0.01 log units) above it, within the range that was stated.
By their numbers in this assay, from the lowest: compounds 1, 3 and 4 (each within the scatter of the next, the first and the last beyond it); then compound 2.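

Within this assay the exchange of fluoro for iodo gives a 1.4-fold higher number from compound 3 to compound 4 (0.16 log units; within the scatter) and so shows that, at this place on the ring, one halogen can replace another without a shift that stands out from the scatter. The 4-iodophenyl group also keeps the separation from the 3-isopropylphenyl compound, with a 3.1-fold lower number from compound 2 to compound 4 (0.50 log units; beyond the scatter) as the step. It differs from the 3-cyanophenyl compound as well, with a 2.3-fold higher number from compound 1 to compound 4 (0.36 log units; beyond the scatter) as the step, a separation that the 4-fluorophenyl compound did not show, although compound 3 and compound 4 lie within the scatter of each other.

From the compounds shown here alone, whether bromo, an amine or a carboxylic acid at this place would leave the number as little changed remains open. No measurement shown here gives a reason for these numbers.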